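Trimming one methyl from a trimethylphenyl amide

The compounds below may be only part of what the source reports. "The series", "measured", "known", "first", "only" and "open" are said of these compounds alone.

Measured compounds:
compound 1 `Cc1cc(C)c(-c2nc(CN3CCC(C(=O)NCCCN4C[C@H](C)C[C@H](C)C4)CC3)c(C)o2)c(C)c1`: "not determined" (no result reported) in a physicochemical assay for permeability, using PAMPA; on this read-out lower numbers stand for lower permeability and higher numbers for higher permeability
compound 2 `Cc1ccccc1-c1nc(CN2CCC(C(=O)N3CCN(CCN(C)C)CC3)CC2)c(C)o1`: 14 10^-6 cm/s

In this assay compound 1 gives "not determined" (no result reported), so nothing can be said of where it stands. Compound 2, which shares the core, gives 14 10^-6 cm/s in this assay. Compound 3 `Cc1ccc(-c2nc(CN3CCC(C(=O)NCCCN4C[C@H](C)C[C@H](C)C4)CC3)c(C)o2)c(C)c1` differs from compound 1 by hydrogen in place of methyl on an aromatic carbon. Among the measured compounds shown here, with no measured pair spanning this change, the step in this assay is expected to be small, likely no further than the usual scatter, in no firm direction. For compound 3 the expected apparent permeability is 10 10^-6 cm/s, within a range of 3 10^-6 cm/s to 25 10^-6 cm/s.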

Compound 3, apparent permeability: 353 10^-6 cm/s
For compound 3 the middle estimate is 35-fold (1.55 log units) below the measured one, outside the stated range (above it).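

In this assay no step can be read between compound 1 and compound 3. What replacing that methyl with hydrogen does to this read-out stays open, and nothing shown offers an explanation for the value of compound 3.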